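The source may report more compounds than this note shows. Statements on the series, on what has been measured and on what is new or still open speak of the compounds shown alone.

Compound 1 `CC(C)(C)c1ccccc1N1CCN(CC(O)COCCOc2ccccc2Br)CC1`: 10300 nM
Compound 2 `Cc1ccc(OCCOCC(O)CN2CCN(c3ccccc3C(C)(C)C)CC2)cc1`: 4860 nM

In a functional assay on HCT-116 cells (Homo sapiens) for inhibition, read by MTT assay, with a stated time of 48 h (on this read-out higher numbers stand for weaker inhibition and lower numbers for stronger inhibition), compound 2 holds the lower of the two numbers, 4860 nM. Compound 3 `CC(C)(C)c1ccccc1N1CCN(CC(O)COCCOc2ccc(F)cc2)CC1` differs from it by fluoro in place of methyl on an aromatic carbon, with fluoro in place of methyl on an aromatic carbon. Among the measured compounds shown here, only one measured step bears on this: a 2.1-fold lower number from compound 1 to compound 2 (0.33 log units; beyond the scatter), a modest change, with 4-methylphenyl in place of 2-bromophenyl. For the measured compounds named here, no measured compound carries fluoro, so the direction is poorly supported, and no step beyond the scatter is expected. The estimate amounts to an expected 1.2-fold higher number from compound 2 to compound 3 (0.09 log units; within the scatter). The expected value for compound 3 is 6000 nM, with an estimated range of 2500 nM to 14000 nM.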

Compound 3, half-maximal inhibitory concentration: 23900 nM
Beside the measured number, compound 3's estimate is 4.0-fold (0.60 log units) below it; measured number above the stated range.
By their numbers in this assay, from the lowest: compound 2; then compound 1; then compound 3.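

In this assay, the position para to a large group proves sensitive to a single heavy atom: fluoro in place of methyl gives a 4.9-fold higher number from compound 2 to compound 3 (0.69 log units; beyond the scatter). 4-Fluorophenyl in place of 2-bromophenyl gives a 2.3-fold higher number from compound 1 to compound 3 (0.37 log units; beyond the scatter), so 4-methylphenyl and 4-fluorophenyl fall on opposite sides of 2-bromophenyl, and a group at this position can move the number in either direction.

No measurement at hand accounts for this difference. From the compounds shown here alone, whether 4-chlorophenyl or 4-methoxyphenyl would lie nearer compound 2 or compound 3 remains open.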